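The source may report more compounds than this note shows. Statements on the series, on what has been measured and on what is new or still open speak of the compounds shown alone.

Compound 1 `C/C(=N\C(C)C)c1c(O)c2ccccc2[nH]c1=O` — >= 100000 nM, a limit of the assay
Compound 2 `C/C(=N\Nc1ccccc1)c1c(O)c2ccccc2oc1=O` — 27000 nM
Compound 3 `C/C(=N\CC1CCCCC1)c1c(O)c2ccccc2[nH]c1=O` — >= 100000 nM, a limit of the assay

All three were tested in an assay on isolated protein for inhibition of myosin-2 (Bos taurus), read by spectrophotometry, with a stated time of 24 min; on this read-out lower numbers stand for stronger inhibition and higher numbers for weaker inhibition. For the measured compounds named here, compound 2 is the only one that gives a number, 27000 nM. Compound 1 reaches only a limit of the assay, >= 100000 nM. Compound 3 also gives only a limit, >= 100000 nM. Going by the values given here, the single step between measured compounds, a step that the two limits leave unreadable from compound 1 to compound 3, cannot be read as a size, since both of its ends sit at the limit of >= 100000 nM in this assay, at which 2 of the 3 values shown sit.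

Compound 4 `C/C(=N\CCCO)c1c(O)c2ccccc2oc1=O` has not yet been measured. It differs from compound 2 in one place: 3-hydroxypropyl in place of anilino on a double-bonded nitrogen. Among the compounds with values here, no measured step covers a change of this kind, and the one step that exists is unreadable, so the expectation rests on where the three compounds stand. Within the data shown here, compound 2, with anilino on the double-bonded nitrogen, is the only compound with a measurable value, while compounds 1 and 3, carrying isopropyl and cyclohexylmethyl there, sit at the limit. Compound 4 is therefore expected to be weaker in this assay, with an estimated 90000 nM and a range from 25000 nM to 300000 nM. The expected step is a 3.3-fold higher number from compound 2 to compound 4 (0.52 log units; beyond the scatter) in this assay, with a real chance that only a limit is reported.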

Compound 4, half-maximal inhibitory concentration: 37000 nM
Compound 4: middle estimate off by 2.4-fold (0.39 log units), on the high side, and the stated range covers the measured number.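

In this assay, putting 3-hydroxypropyl in place of anilino on the double-bonded nitrogen gives a 1.4-fold higher number from compound 2 to compound 4 (0.14 log units; within the scatter), so this read-out does not separate the two compounds. For the compounds shown here, until now compound 2 was the only compound with a number, and nothing showed whether that number depended on anilino. The change removes the six-membered aromatic ring and goes from 7 heavy atoms to 4, while the count of hydrogen-bond donors and acceptors stays the same, so on this core a ring at this place is not needed for a measurable number in this assay.

As far as these compounds go, whether the hydroxyl at the end of the chain matters stays open, and a plain propyl chain, an amine or a carboxylic acid at that end, or a longer chain on the same core would bear on that. Compounds 1 and 3 differ from compound 2 and compound 4 in the core as well as on this nitrogen, so they cannot speak to this change, and the step between them stays unreadable, both of its ends being limits of the assay: the limit of >= 100000 nM in this assay, at which 2 of the 4 values shown sit.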